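The compounds below may be only part of what the source reports. "The series", "measured", "known", "first", "only" and "open" are said of these compounds alone.

Working notes on the series. Three compounds have been run in a functional assay on SJSA-1 cells (Homo sapiens) for inhibition, read by CCK-8 assay, with a stated time of 72 h, tested at 1 uM; a higher number here means more inhibition at the concentration tested (going by the name of the read-out), a lower number less inhibition. Compound 1 `COc1ccccc1N1C(=O)C(C)SC1c1cccc(C(=O)NCCCCc2ccccc2)c1` gives 84%. Compound 2 `COc1ccccc1N1C(=O)CSC1c1cc(F)cc(C(=O)O)c1` gives 0%. Compound 3 `COc1ccc(C)cc1N1C(=O)CSC1c1cccc(C(=O)NCCCCc2ccccc2)c1` gives 79%. On these numbers compound 3 sits at the upper end together with compound 1, the two values lying within the usual scatter of each other, while compound 2 lies far below both, beyond the scatter. For the measured compounds named here, no pair of measured compounds differs in a single place, so no step can be set out; compound 2 differs from compound 3 in several places at once and its low number cannot be tied to any one of them.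

Compound 4 `COc1cc(F)ccc1N1C(=O)CSC1c1cccc(C(=O)NCCCCc2ccccc2)c1` has not yet been measured. Against compound 3 the change is 4-fluoro-2-methoxyphenyl in place of 2-methoxy-5-methylphenyl on an amide-type nitrogen in a ring. Compound 1 and compound 3 carry small differences around the shared core and the same amide tail, yet give numbers within the scatter of each other. The step from compound 3 to compound 4 in this assay is therefore expected to be a number 4 percentage points lower from compound 3 to compound 4 (within the scatter), none beyond the scatter, because compound 1 at 84% and compound 3 at 79% suggest that small changes on the aryl on the ring nitrogen leave the read-out much the same. Compound 4 is expected to give 75%, with a range from 55% to 90%.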

Compound 4, a percentage reported as inhibition, at one concentration (the size of the read-out at that concentration, not a potency): 77%
Compound 4: the middle estimate sits 2 percentage points below what was measured; measured number inside the range.
By their numbers in this assay, from the lowest: compound 2; then compounds 4, 3 and 1 (each within the scatter of the next).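

For the compounds shown here, the exchange of 2-methoxy-5-methylphenyl for 4-fluoro-2-methoxyphenyl on an amide-type nitrogen in a ring gives, in this assay, a number 2 percentage points lower from compound 3 to compound 4 (within the scatter) and is the first change that can be read in one place. Going by these compounds alone, with the methoxy group kept on the ring, this position therefore takes a fluorine in place of a methyl, each at its own ring position, with no step beyond the scatter, which the earlier compounds could only hint at because they differ in more than one place. No measurement on hand offers an explanation for this result.

From the compounds shown here alone, the read-out is a percentage at one concentration and not a potency, so any difference between compound 3 and compound 4 that this single reading does not resolve stays open. The compounds shown also leave open whether the read-out holds when the aryl on the ring nitrogen carries a group other than these, such as a dimethylamino group or a trifluoromethyl group, or gives way to a pyridine ring or an unsubstituted phenyl.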